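The source may hold more compounds than are shown below. What is called first, only, known or untested is meant among the compounds shown, and "the series" means these compounds.

Of the compounds shown here, three that share one core have been measured so far, and a fourth is about to be. Compound 1 `CC(C)c1c(C(=O)N(C)Cc2ccccc2)nn(-c2ccc(F)cc2)c1OC[C@@H](O)C[C@@H](O)CC(=O)O` gives 5.2 nM in an assay on microsomes from liver for inhibition of 3-hydroxy-3-methylglutaryl-coenzyme A reductase (Rattus norvegicus); a lower number here means a stronger inhibitor, a higher number a weaker inhibitor. Compound 2 `COc1ccc(CNC(=O)c2nn(-c3ccc(F)cc3)c(OC[C@@H](O)C[C@@H](O)CC(=O)O)c2C(C)C)cc1` gives 12 nM in this assay, and compound 3 `CC(C)c1c(C(=O)NCc2ccccc2Cl)nn(-c2ccc(F)cc2)c1OC[C@@H](O)C[C@@H](O)CC(=O)O` gives 9.5 nM. Compound 3 thus has the second highest of the three numbers; its nearest neighbour is compound 2, and the gap between them is within the scatter, as is the gap to compound 1.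

Compound 4 `CC(C)c1c(C(=O)N(C)Cc2ccc(F)c(F)c2)nn(-c2ccc(F)cc2)c1OC[C@@H](O)C[C@@H](O)CC(=O)O` is reached from compound 3 by a change on a carbonyl carbon: (3,4-difluorobenzyl)(methyl)amino in place of (2-chlorobenzyl)amino on a carbonyl carbon. For the measured compounds named here, two measured steps bear on it. Going by the values given here, the step from compound 1 to compound 3 a 1.8-fold higher number from compound 1 to compound 3 (0.26 log units; within the scatter) shows what removing the methyl from the amide nitrogen and placing a chlorine on the ring did; compound 4 restores the methyl, drops the chlorine, and adds two fluorines to the ring, which no measured step covers. The step of a 2.3-fold higher number from compound 1 to compound 2 (0.36 log units; beyond the scatter) shows that a ring substituent can shift the number modestly, while the step of a 1.3-fold lower number from compound 2 to compound 3 (0.10 log units; within the scatter) shows a swap of ring substituents that stayed within the scatter. Taken together, compound 4 is expected to sit close to compound 1, and the expected step of a 1.6-fold lower number from compound 3 to compound 4 (0.20 log units; within the scatter) should stay within the scatter. Compound 4 is therefore estimated at 6 nM, most likely between 3 nM and 15 nM.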

Compound 4, half-maximal inhibitory concentration: 5.7 nM
Compound 4: middle estimate off by 1.1-fold (0.02 log units), on the high side; the measured number falls inside the stated range.
By their numbers in this assay, from the lowest: compounds 1, 4, 3 and 2 (each within the scatter of the next, the first and the last beyond it).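

In this assay the ring of compound 1 takes two fluorines with no readable shift: 3,4-difluorophenyl in place of phenyl gives a 1.1-fold higher number from compound 1 to compound 4 (0.04 log units; within the scatter) and leaves the methyl on the amide-type nitrogen untouched. Set against the groups that keep the amide hydrogen, (3,4-difluorobenzyl)(methyl)amino gives a 2.1-fold lower number from compound 2 to compound 4 (0.32 log units; beyond the scatter) but only a 1.7-fold lower number from compound 3 to compound 4 (0.22 log units; within the scatter) and so compound 3 stands against any simple rule that the methylated amides always give the lower number. No measurement shown gives a reason for any of these steps.

Going by these compounds, both of those swaps alter the ring and the nitrogen together, so what the methyl contributes alone stays open. Also open, on these data alone, is how an ethyl on the amide-type nitrogen, or a nitrile on the ring, would shift the number.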